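Trimming a Pentylsulfanyl Chain Down to Methylsulfanyl

The source may report more compounds than this note shows. Statements on the series, on what has been measured and on what is new or still open speak of the compounds shown alone.

Of the compounds shown here, two have so far been tested in a functional assay on HTB-54 cells (Homo sapiens) for cytotoxicity, read by MTT assay, with a stated time of 72 h; a lower number here means a stronger inhibitor of growth, a higher number a weaker inhibitor of growth. Compound 1, `COc1ccc(CNc2nc(SC)nc3ncccc23)cc1`, yields only a limit: in this assay compound 1 reads > 100000 nM, which is a limit of the assay rather than a measured number. Compound 2, `CCCCCSc1nc(NCc2ccc([Se]C)cc2)c2ccccc2n1`, gives 50000 nM in this assay. Of the two results shown, compound 2 therefore holds the only actual number, while the other entry sits at the limit (the limit of > 100000 nM in this assay, at which 1 of the 2 values shown sits). Compound 3, `CSc1nc(NCc2ccc([Se]C)cc2)c2ccccc2n1`, has not yet been measured. It differs from compound 2 in one place: hydrogen in place of butyl on a saturated chain carbon bound to a sulfur, so that the pentylsulfanyl group of compound 2 becomes a methylsulfanyl group. Within the data shown here, no measured pair in this set shows this particular change, so its size cannot be read from the data. The expected step is a 1.6-fold higher number from compound 2 to compound 3 (0.20 log units; within the scatter), pointing toward weaker growth inhibition or no change beyond the usual scatter. Compound 3 is accordingly estimated at 80000 nM in this assay, with a range from 30000 nM to 200000 nM, and a real chance that only a limit is reported.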

Compound 3, concentration for total growth inhibition: > 100000 nM
Compound 3 was reported as a limit (the forecaster's own chance of this, stated with the estimate: 45%); at least 1.2-fold (0.09 log units) between middle value and limit.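

Among these compounds, this is the first step in the set that can be read at this position: in this assay, replacing butyl with hydrogen on a saturated chain carbon bound to a sulfur, which turns pentylsulfanyl into methylsulfanyl, gives an at least 2.0-fold higher number from compound 2 to compound 3 (0.30 log units; that floor lies within the scatter). From the compounds shown here alone, the result for compound 3 is a limit and not a number, so the step gives only a floor, and the true size of the change remains unknown. The methylsulfanyl group shows no sign of stronger growth inhibition here, and compound 2 still holds the only actual number, while the other results sit at one shared limit: the limit of > 100000 nM in this assay, at which 2 of the 3 values shown sit.

The compounds shown leave open how the number would respond to a propyl group on the sulfur, which lies in length between methyl and pentyl, or to a longer chain such as octyl. They also leave open what a chain ending in an amine or a carboxylic acid would do, and with one actual number in hand, no trend with chain length can yet be drawn.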